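Bromo on the Phenyl Ring of a Chromone Ether

A few compounds are considered here, and "the series" means these few. Any claim that something is new, unique, unknown or untested is made for them only; others in the source may bear on it.

Measured compounds:
compound 1 `O=c1ccoc2ccc(OCCc3ccccc3)cc12` 3120 nM
compound 2 `Cc1ccc(COc2ccc3occc(=O)c3c2)cc1` 3490 nM

In an assay on microsomes for inhibition of Amine oxidase [flavin-containing] A (Homo sapiens), read by fluorescence and spectrophotometry, with a stated time of 20 min (on this read-out higher numbers stand for weaker inhibition and lower numbers for stronger inhibition), compound 1 gives 3120 nM, and compound 2 gives 3490 nM; the two numbers lie within the scatter of each other, so neither stands apart. Compound 3 `O=c1ccoc2ccc(OCCc3ccc(Br)cc3)cc12` has not been measured. It differs from compound 1 by bromo in place of hydrogen on an aromatic carbon, on an aromatic carbon of a six-membered aromatic ring of carbon only, para to a large group. Within the data shown here, no step between measured compounds is known that could guide this change. A modest step toward stronger inhibition is expected, with a step of a 2.1-fold lower number from compound 1 to compound 3 (0.32 log units; beyond the scatter), so that compound 3 is estimated at 1500 nM, in a range from 500 nM to 5000 nM.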

Compound 3, half-maximal inhibitory concentration: 480 nM
Compound 3: the middle estimate sits 3.1-fold (0.49 log units) above what was measured, outside the stated range (below it).
By their numbers in this assay, from the lowest: compound 3; then compounds 1 and 2 (each within the scatter of the next).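

In this assay, the change from phenyl to 4-bromophenyl gives a 6.5-fold lower number from compound 1 to compound 3 (0.81 log units; beyond the scatter) with the addition of a single heavy atom. Among these compounds, no step was known at this place before, and this one shows that the aromatic carbon para to a large group responds clearly to bromo in place of hydrogen. Nothing at hand accounts for the size of this step.

The compounds shown leave open whether chloro, methoxy or an amine in the same place would move the number as bromo does. They also leave open whether the step would hold with a longer chain.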